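This account rests on a few compounds, and the source may have more. Where it says the series, first, only, none or still open, it means among the compounds named here.

Series notes. Compound 3 `CCCCOc1cccc(N/C(=N/O)c2ccc3occc3c2)c1` is the butoxy member of the set. In an assay on isolated protein for inhibition of Indoleamine 2,3-dioxygenase 1 (Homo sapiens), read by spectrophotometry (on this read-out lower numbers stand for stronger inhibition and higher numbers for weaker inhibition), compound 3 comes back only as a limit of the measurement, > 30000 nM. Compound 1 `O/N=C(/Nc1cccc(F)c1)c1ccc2occc2c1` carries fluoro at the same place, and in this assay compound 1 gives 32700 nM. Compound 2 `CC1CCN(C(=O)c2cccc(N/C(=N/O)c3ccc4occc4c3)c2)CC1` carries the (4-methylpiperidin-1-yl)carbonyl group, and in this assay compound 2 likewise comes back only as a limit, > 30000 nM. Within the data shown here, the three steps among them, a step that the limit leaves unreadable from compound 1 to compound 2, a step that the limit leaves unreadable from compound 1 to compound 3 and a step that the two limits leave unreadable from compound 2 to compound 3, cannot be sized, as the limit of > 30000 nM in this assay, at which 2 of the 3 values shown sit, shows, so none of the measured steps gives a readable direction. Compound 4 `O/N=C(/Nc1cccc(Oc2ccccc2)c1)c1ccc2occc2c1` differs from compound 3 by phenyl in place of butyl on an oxygen on an aromatic ring. Among the measured compounds shown here, no measured step bears on this exact change; all three measured compounds sit at the weak end of the read-out. For compound 4 the expected step is a number no higher from compound 3 to compound 4 (the limit leaves the size open), none beyond the scatter. The estimate for compound 4 in this assay is 30000 nM, with a range from 8000 nM to 100000 nM.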

Compound 4, half-maximal inhibitory concentration: > 30000 nM
Compound 4 ended at the assay's limit; the forecaster's own chance of this, stated with the estimate: 60%; the middle value sits exactly at the limit.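

In this assay no new step can be read from compound 4 to compound 1, compound 2 or compound 3, because the values stop at a limit: the limit of > 30000 nM in this assay, at which 3 of the 4 values shown sit.
The compounds shown leave open how large these steps are, and whether any group at this place gives a readable value clear of the limit.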